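A few compounds are considered here, and "the series" means these few. Any claim that something is new, unique, unknown or untested is made for them only; others in the source may bear on it.

Measured compounds in a functional assay on BGC-823 cells (Homo sapiens) for antiproliferative activity, read by MTT assay, tested at 5 uM; a higher number here means a stronger effect of the compound at the concentration tested, a lower number a weaker effect:
Compound 1 `COc1cc(C2=NN(C(C)=O)C(c3cc(Cl)cc(Cl)c3)O2)cc(OC)c1OC`; compound 1 gives 6.6%.
Compound 2 `COc1ccc(C2OC(c3cc(OC)c(OC)c(OC)c3)=NN2C(C)=O)c(OC)c1`; compound 2 gives -3.1%.

Both compounds share the same core and differ only in the aryl group on a saturated ring carbon. Compound 2 sits at the same level as compound 1 within the usual scatter of this kind of measurement, the gap being a number 9.7 percentage points lower from compound 1 to compound 2 (within the scatter), so neither can be called the more active one.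

Compound 3 `COc1ccc(OC)c(C2OC(c3cc(OC)c(OC)c(OC)c3)=NN2C(C)=O)c1` has not been measured. It keeps every atom of compound 2, rearranged: 2,5-dimethoxyphenyl in place of 2,4-dimethoxyphenyl on a saturated ring carbon.

Among the measured compounds shown here, the only measured step that bears on this change, a number 9.7 percentage points lower from compound 1 to compound 2 (within the scatter), swapped one aryl group for another on the same saturated ring carbon and stayed within the scatter. A swap between two dimethoxyphenyl groups is therefore expected to move this assay by no more than the scatter. For compound 3 the expected step is a number 3.1 percentage points higher from compound 2 to compound 3 (within the scatter), and compound 3 is estimated at 0%, within -12% to 12%.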

Compound 3, a percentage reported as inhibition, at one concentration (the size of the read-out at that concentration, not a potency): 18.2%
The estimate for compound 3 lay 18.2 percentage points below the measured number, outside the stated range (above it).
By their numbers in this assay, from the lowest: compounds 2 and 1 (each within the scatter of the next); then compound 3.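

In this assay, rearranging the same atoms from a 2,4-dimethoxyphenyl to a 2,5-dimethoxyphenyl group on the saturated ring carbon gives a number 21.3 percentage points higher from compound 2 to compound 3 (beyond the scatter), so the placement of the two methoxy groups matters here, even with the heavy-atom count and the counted hydrogen-bond acceptors unchanged. The 2,5-dimethoxyphenyl group also stands apart from the 3,5-dichlorophenyl group, with a number 11.6 percentage points higher from compound 1 to compound 3 (beyond the scatter), a separation that the earlier swap between compounds 1 and 2 did not show. Nothing available here accounts for this difference.

With one tested concentration, these numbers give no potency, and three aryl groups cannot show how far the effect of this position extends. On these data alone, whether a 3,4-dimethoxyphenyl group, an aminophenyl group or a carboxyphenyl group would raise or lower the number remains open.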